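Cytotoxicity notes on a thiazole-piperidine series

The compounds below may be only part of what the source reports. "The series", "measured", "known", "first", "only" and "open" are said of these compounds alone.

Measured so far:
compound 1, `CCc1cnc(N2CCC(c3nc(COc4ccc(-n5cnnn5)cc4)cs3)CC2)nc1` — > 100000 nM
compound 2, `CCc1cnc(N2CCC(c3nc(COc4ccc(/C=C5\CC(=O)NC5=O)cc4F)cs3)CC2)nc1` — > 100000 nM

Both measured compounds were run in an ADME assay on CHO-K1 cells (Cricetulus griseus) for cytotoxicity; a lower number here means a stronger inhibitor, a higher number a weaker inhibitor. Compound 1 gives only a limit, > 100000 nM, not a number. Compound 2 likewise gives only a limit, > 100000 nM. On the numbers shown, compound 2 therefore stands at the upper edge of the assay, with no measurable cytotoxicity, and the single other value shown sits at the same edge; no step between measured compounds can be computed, and nothing in the pair separates the two.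

Compound 3, `CCc1cnc(N2CCC(c3nc(COc4ccc(/C=C5\CC(=O)NC5=O)cc4C)cs3)CC2)nc1`, has not yet been measured. It differs from compound 2 in one place: methyl in place of fluoro on an aromatic carbon. The change is confined to a single heavy atom on the aromatic carbon described, with no change in ring count, donors, acceptors or charge.

Since both values shown sit at the limit, because of the limit of > 100000 nM in this assay, at which 2 of the 2 values shown sit, no shift in cytotoxicity beyond the scatter is expected from compound 2 to compound 3; the expected step is a step that the limit leaves unreadable from compound 2 to compound 3, that is, none of consequence. Compound 3 is estimated at 150000 nM, within 50000 nM to 500000 nM, most likely reported again only as a limit.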

Compound 3, half-maximal inhibitory concentration: > 100000 nM
Compound 3 ended at the assay's limit; the forecaster's own chance of this, stated with the estimate: 85%; the middle value is on the limit's open side.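

No step can be read from compound 2 to compound 3 in this assay, as both results are limits and not numbers, so methyl in place of fluoro on an aromatic carbon has no readable size: the limit of > 100000 nM in this assay, at which 3 of the 3 values shown sit.

The compounds shown leave open whether any compound in this series reaches a measurable cytotoxicity in this assay and how that swap would then read.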